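Carbamate in Place of a Neopentyl Amide

The compounds below may be only part of what the source reports. "The series", "measured", "known", "first", "only" and "open" are said of these compounds alone.

Of the compounds shown here, three sharing one core have been measured in an assay on CHO-K1 cells for displacement of a labelled ligand from prostaglandin E2 receptor EP1 subtype (Homo sapiens); on this read-out higher numbers stand for weaker inhibition and lower numbers for stronger inhibition. Compound 1 `Cc1cc(C(N)=O)nn1Cc1cc(Cl)ccc1OCc1ccccc1` gives 126 nM. Compound 2 `Cc1cc(C(=O)Nc2cccc(F)c2)nn1Cc1cc(Cl)ccc1OCc1ccccc1` gives 200 nM, and the step of a 1.6-fold higher number from compound 1 to compound 2 (0.20 log units; within the scatter) lies within the scatter. Compound 3 `Cc1cc(NC(=O)CC(C)(C)C)nn1Cc1cc(Cl)ccc1OCc1ccccc1` gives 10 nM, the lowest number of the three: the step of a 13-fold lower number from compound 1 to compound 3 (1.10 log units; beyond the scatter) and the step of a 20-fold lower number from compound 2 to compound 3 (1.30 log units; beyond the scatter) are both large, so compound 3 stands apart from the other two.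

Compound 4 `Cc1cc(NC(=O)O[C@H]2CCOC2)nn1Cc1cc(Cl)ccc1OCc1ccccc1` differs from compound 3 in one place: (oxolan-3-yl)oxy in place of neopentyl on a carbonyl carbon. Among the measured compounds shown here, no measured step in this assay alters this part of compound 3, so nothing here tells directly what the new group will do. The two steps that bear on the question, the step from compound 1 and the step from compound 2 to compound 3, both show that the group hanging from the amide-type nitrogen governs the number, and that the neopentylcarbonyl version is the best seen. Replacing the neopentyl by (oxolan-3-yl)oxy is therefore expected to move the number upward by a modest amount, with the step of a 3.0-fold higher number from compound 3 to compound 4 (0.48 log units; beyond the scatter) taken as the expectation. Compound 4 is estimated at 30 nM, with a range from 8 nM to 120 nM.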

Compound 4, half-maximal inhibitory concentration: 79.4 nM
Compound 4: middle estimate off by 2.6-fold (0.42 log units), on the low side; the measured number falls inside the stated range.
By their numbers in this assay, from the lowest: compound 3; then compounds 4, 1 and 2 (each within the scatter of the next, the first and the last beyond it).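

In this assay the carbonyl carbon attached to the amide-type nitrogen proves sensitive to what it carries, as the first change made at this position gives a 7.9-fold higher number from compound 3 to compound 4 (0.90 log units; beyond the scatter) and the advantage held by the neopentylcarbonyl version does not carry over to the ((oxolan-3-yl)oxy)carbonyl version. The new group keeps some advantage over the (3-fluorophenyl)carbamoyl group, with a 2.5-fold lower number from compound 2 to compound 4 (0.40 log units; beyond the scatter), but it cannot be told apart from the plain carbamoyl group, since a 1.6-fold lower number from compound 1 to compound 4 (0.20 log units; within the scatter) lies within the scatter, so among these four compounds only compound 3 stands apart from the rest. No measured evidence is available to explain why the number moves with this change.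

The step from compound 3 to compound 4 replaces the chain with a ring and brings in oxygen at the same time, so the compounds shown cannot say which of these differences goes with the higher number. A tert-butoxy group or a cyclopentyl group on the same carbonyl carbon would separate the two, and the mirror-image oxolan-3-yl group would show whether the defined stereocentre matters.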